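A few compounds are considered here, and "the series" means these few. Any claim that something is new, unique, unknown or untested is made for them only; others in the source may bear on it.

Measured so far in a functional assay on KB cells (Homo sapiens) for antiproliferative activity, read by MTT assay, with a stated time of 72 h; on this read-out higher numbers stand for weaker inhibition and lower numbers for stronger inhibition:
- compound 1 `COc1ccc(-c2cc(C(=O)O)sc2-c2cc(OC)c(OC)c(OC)c2)cc1OCc1ccccc1`: > 100000 nM
- compound 2 `COc1ccc(-c2cc(C(=O)O)sc2-c2cc(OC)c(OC)c(OC)c2)cc1O`: 21800 nM
- compound 3 `COc1ccc(-c2ccsc2-c2cc(OC)c(OC)c(OC)c2)cc1OCc1ccccc1`: > 100000 nM

The value of compound 1 in this assay is a limit of the assay, not a number. Compound 2 differs from compound 1 by one change, (hydrogen in place of benzyl on an oxygen on an aromatic ring), and in this assay compound 2 gives 21800 nM. The step of an at least 4.5-fold lower number from compound 1 to compound 2 (0.66 log units; beyond the scatter) is read against (the limit of > 100000 nM in this assay, at which 2 of the 3 values shown sit), so only its lower bound is known. Compound 3 differs from compound 1 in the core, (hydrogen in place of carboxy on an aromatic carbon). The value of compound 3 in this assay is again a limit. The step that the two limits leave unreadable from compound 1 to compound 3 therefore cannot be read.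

Compound 4 `COc1ccc(-c2ccsc2-c2cc(OC)c(OC)c(OC)c2)cc1O` is not yet measured. It differs from compound 3 by hydrogen in place of benzyl on an oxygen on an aromatic ring, the same change as from compound 1 to compound 2, made at the same kind of place. In this assay the expected step is an at least 2.5-fold lower number from compound 3 to compound 4 (0.39 log units; beyond the scatter), resting on the earlier step of an at least 4.5-fold lower number from compound 1 to compound 2 (0.66 log units; beyond the scatter), with the caution that the starting point is a limit. Compound 4 is estimated at 40000 nM, somewhere between 10000 nM and 200000 nM.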

Compound 4, half-maximal inhibitory concentration: 1530 nM
Beside the measured number, compound 4's estimate is 26-fold (1.42 log units) above it; measured number below the stated range.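

In this assay, putting hydrogen in place of benzyl lowers the number on both cores, and on the core without the carboxy group it gives an at least 65-fold lower number from compound 3 to compound 4 (1.81 log units; beyond the scatter). Compound 3 stands at > 100000 nM, which is a limit of the assay and not a number, so this step has only a lower bound. The direction of the change therefore carries from one core to the other, but these compounds do not show whether its size is the same on both: the same change on two cores in this assay, an at least 4.5-fold lower number (0.66 log units; beyond the scatter) from compound 1 to compound 2 and an at least 65-fold lower number (1.81 log units; beyond the scatter) from compound 3 to compound 4; the limit leaves it open whether they differ

Taking away the carboxy group while the hydroxy is present gives a 14-fold lower number from compound 2 to compound 4 (1.15 log units; beyond the scatter), but the same step with benzyloxy present cannot be read, which leaves open whether this second change carries over in the same way. Also open, as far as these compounds go, is what an amine or a longer ether chain would do in place of the hydroxy, and what an amide would do in place of the carboxylic acid.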